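Three fluorines in place of one on the phenoxy tail

The source may report more compounds than this note shows. Statements on the series, on what has been measured and on what is new or still open speak of the compounds shown alone.

Compound 3 `CC(C)[C@H](NC(=O)COc1cccc2ccccc12)C(=O)N[C@@H](CC(=O)O)C(=O)COc1ccc(F)cc1` carries a 4-fluorophenyl on an oxygen on a saturated carbon. In a functional assay on Jurkat cells (Homo sapiens) (a lower number here means a stronger inhibitor, a higher number a weaker inhibitor), compound 3 gives only a limit, > 100000 nM. Compound 1 `CC(=O)Nc1cccc(OCC(=O)[C@H](CC(=O)O)NC(=O)[C@@H](NC(=O)COc2cccc3ccccc23)C(C)C)c1`, which instead carries a 3-acetamidophenyl at that oxygen, also returns only a limit in this assay, namely > 100000 nM. Compound 2 `CC(C)[C@H](NC(=O)COc1cccc2ccccc12)C(=O)N[C@@H](CC(=O)O)C(=O)COc1ccccc1[N+](=O)[O-]`, with a 2-nitrophenyl there, likewise stops at the limit > 100000 nM in this assay. The steps among these three, a step that the two limits leave unreadable from compound 1 to compound 2, a step that the two limits leave unreadable from compound 1 to compound 3 and a step that the two limits leave unreadable from compound 2 to compound 3, are unreadable: each side is a limit rather than a number. What the measurements do show is the limit of > 100000 nM in this assay, at which 3 of the 3 values shown sit.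

Compound 4 `CC(C)[C@H](NC(=O)COc1cccc2ccccc12)C(=O)N[C@@H](CC(=O)O)C(=O)COc1cc(F)c(F)cc1F` differs from compound 3 in one place: 2,4,5-trifluorophenyl in place of 4-fluorophenyl on an oxygen on a saturated carbon. Going by the values given here, no measured step bears on this change in a readable way. Among the compounds with values here, because the limit of > 100000 nM in this assay, at which 3 of the 3 values shown sit, shows every compound so far sitting at the limit, compound 4 is expected to sit there as well, and the expected step of a number no higher from compound 3 to compound 4 (the limit leaves the size open) is none beyond the scatter. The estimate for compound 4 in this assay is 100000 nM, within 30000 nM to 300000 nM.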

Compound 4, half-maximal inhibitory concentration: 39300 nM
The estimate for compound 4 lay 2.5-fold (0.41 log units) above the measured number; the measured number falls inside the stated range.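

Going by these compounds alone, compound 4 is the only one of the four compounds that gives a number rather than a limit in this assay, so the group on this oxygen can move the read-out away from the limit. Putting 2,4,5-trifluorophenyl in place of 4-fluorophenyl gives an at least 2.5-fold lower number from compound 3 to compound 4 (0.40 log units; beyond the scatter), and the same group gives an at least 2.5-fold lower number from compound 2 to compound 4 (0.40 log units; beyond the scatter) against 2-nitrophenyl and an at least 2.5-fold lower number from compound 1 to compound 4 (0.40 log units; beyond the scatter) against 3-acetamidophenyl. Each of these steps is a minimum size, one end of each being a limit, the steps among the other compounds cannot be read, and the activity remains weak across the set: the limit of > 100000 nM in this assay, at which 3 of the 4 values shown sit.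

From the compounds shown here alone, it remains open which of the three fluorines matters, a question that 2,4-difluorophenyl or 3,4-difluorophenyl could help to settle. Going by these compounds, it is also open whether other groups, such as 2,4,5-trichlorophenyl or pentafluorophenyl, would lower the number further.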